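The source may hold more compounds than are shown below. What is called first, only, known or untested is meant among the compounds shown, and "the series" means these compounds.

Measured compounds:
Compound 1, `COc1ccc(-c2nnc(SC/C(=N/O)c3ccccc3)n2-c2ccccc2)cc1`: 63%
Compound 2, `C=CCn1c(SC/C(=N/O)c2ccccc2)nnc1-c1ccc(OC)cc1`: 66%
Compound 3, `C=CCn1c(SC/C(=N/O)c2ccccc2)nnc1-c1cc(OC)c(OC)c(OC)c1`: 68%

All three were tested in a functional assay on the whole organism (strain albino) for inhibition, with Rattus norvegicus as the target, read by paw edema, with a stated time of 2 h, at a dose of 0.28 mmol/kg by the oral route; on this read-out higher numbers stand for more inhibition at the one dose given (going by the name of the read-out) and lower numbers for less inhibition. Going by the values given here, the three numbers lie close together, and none of the gaps between them is beyond the usual scatter, so no compound can be said to give the highest or the lowest number of the set.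

Compounds 2 and 1 differ in one place only: phenyl in place of allyl on an aromatic nitrogen. This change gave a number 3 percentage points lower from compound 2 to compound 1 (within the scatter). Compound 2 and compound 3 share the same change-point but differ elsewhere; the difference between the two cores is not broken down here.

Compound 4, `COc1cc(-c2nnc(SC/C(=N/O)c3ccccc3)n2-c2ccccc2)cc(OC)c1OC`, has not yet been tested in this assay. It differs from compound 3 by phenyl in place of allyl on an aromatic nitrogen. Among the compounds with values here, this is the same kind of change as the one from compound 2 to compound 1, not the same: there the ring nitrogen was next to the ring atom that bears a 4-methoxyphenyl group and next to the ring atom that bears a large group, whereas here it is next to two ring atoms that each bear a large group.

Because the earlier step of a number 3 percentage points lower from compound 2 to compound 1 (within the scatter) stayed within the scatter, the step from compound 3 to compound 4 is expected to be about as small, namely a number 3 percentage points lower from compound 3 to compound 4 (within the scatter). Compound 4 is therefore estimated to give 65%, expected between 55% and 75%, resting on one measured pair only.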

Compound 4, a percentage reported as inhibition, in the whole organism at one dose (the size of the read-out at that dose, not a potency): 61%
The estimate for compound 4 lay 4 percentage points above the measured number, and the stated range covers the measured number.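

In this assay, putting phenyl in place of allyl on an aromatic nitrogen gave a number 7 percentage points lower from compound 3 to compound 4 (within the scatter). Set beside the earlier step on the other core, this suggests that the change can be carried from one core to the other in this series without a detectable difference in its size: the same change on two cores in this assay, a number 3 percentage points lower (within the scatter) from compound 2 to compound 1 and a number 7 percentage points lower (within the scatter) from compound 3 to compound 4, 4 percentage points apart, within the scatter of two such steps This does not show that phenyl and allyl truly differ on either core, since neither step stands clear of the scatter, nor does agreement across two pairs, each read at a single dose and a single time, show that the change would behave in the same way on a further core.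

The compounds shown carry only allyl or phenyl on that ring nitrogen, so it remains open how a small methyl group, a longer chain such as butyl, a benzyl group or a chain ending in an amine would compare there. On these data alone, it also remains open whether a carboxylic acid in place of the oxime would leave the inhibition of paw swelling at a similar level.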